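A few compounds are considered here, and "the series" means these few. Any claim that something is new, unique, unknown or untested is made for them only; others in the source may bear on it.

Measured compounds:
compound 1, `COc1cccc(C(=O)/C=C/c2cc(Br)cc(OC)c2O)c1` — 63.1%
compound 2, `COC(=O)C1=C(N)Oc2c(OC)cc(Br)cc2C1CC(=O)c1ccc(Br)cc1` — 31.9%
compound 3, `COC(=O)C1=C(N)Oc2ccc(Br)cc2C1CC(=O)c1ccc(Br)cc1` — 34.8%

In a functional assay on MCF7 cells (Homo sapiens) for antiproliferative activity, read by sulforhodamine B assay, with a stated time of 72 h, tested at 30 uM (a lower number here means a stronger effect, a higher number a weaker effect of the compound at the concentration tested), compound 3 stands second highest of the three numbers; its nearest neighbour is compound 2, with the step of a number 2.9 percentage points higher from compound 2 to compound 3 (within the scatter), and the furthest is compound 1, whose value lies beyond the scatter from that of compound 3. The unmeasured compound 4, `COC(=O)C1=C(N)Oc2ccc(Br)cc2C1CC(=O)c1ccccc1`, differs from compound 3 by hydrogen in place of bromo on an aromatic carbon. Among the measured compounds shown here, the single measured step, a number 2.9 percentage points higher from compound 2 to compound 3 (within the scatter), concerns a different change on the other aromatic ring and was within the scatter, so it gives only weak guidance. For the measured compounds named here, no measured pair shows the loss of the bromo on the aromatic carbon of the six-membered ring of carbon only, so the direction of this step is open. The step from compound 3 to compound 4 is estimated as a number 7.2 percentage points higher from compound 3 to compound 4 (within the scatter), a modest weakening that may still fall within the scatter. Compound 4 is expected to give 42%, with a range from 22% to 65%.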

Compound 4, a percentage reported as activity, at one concentration (the size of the read-out at that concentration, not a potency): 41.3%
Compound 4: the middle estimate sits 0.7 percentage points above what was measured; low and high end bracket the measured number.
By their numbers in this assay, from the lowest: compounds 2, 3 and 4 (each within the scatter of the next); then compound 1.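

In this assay, among the compounds shown here, the change from 4-bromophenyl to phenyl gives a number 6.5 percentage points higher from compound 3 to compound 4 (within the scatter), the first reading for any change on this ring. At this place, on an aromatic carbon para to a large group, the bromo can therefore be replaced by hydrogen without a shift beyond the scatter at the one concentration tested, and the earlier change on the other aromatic ring, a number 2.9 percentage points higher from compound 2 to compound 3 (within the scatter), also stayed within the scatter. No measurement on hand offers an explanation for the size of this step.

On these data alone, whether an amine or a carboxylic acid at this same place would move the read-out beyond the scatter remains open. As far as these compounds go, with only one concentration, whether the two compounds would differ in the size of their effect at other concentrations also remains open.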